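The source may hold more compounds than are shown below. What is called first, only, known or untested is meant among the compounds shown, and "the series" means these compounds.

Measured compounds in a functional assay on MV4-11 cells (Homo sapiens) for cytotoxicity, read by MTT assay, with a stated time of 72 h; a higher number here means a weaker inhibitor, a lower number a stronger inhibitor:
compound 1 `CCOC(=O)c1csc2nc(-c3cccc(NC(=O)c4ccco4)c3)cn12` — > 20000 nM
compound 2 `CCOC(=O)c1csc2nc(-c3ccc(NC(=O)Nc4ccc(Br)cn4)cc3)cn12` — 2440 nM

Compound 1 stands only at a limit of this assay, not at a number: the limit of > 20000 nM in this assay, at which 1 of the 2 values shown sits. For the measured compounds named here, compound 2, with a number of its own in this assay, differs from compound 1 in more than one place, so the two values are simply read side by side and no single step between them is drawn.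

Compound 3 `CCOC(=O)c1csc2nc(-c3cccc(NC(=O)CC)c3)cn12` is compound 1 with one change: ethyl in place of furan-2-yl on a carbonyl carbon. Among the measured pair no step of this kind exists to lean on. With compound 1 already at the limit, no step beyond the usual scatter is expected in this assay, and a reading at the limit again is the likelier outcome. Compound 3 is therefore estimated at 25000 nM, within a range of 8000 nM to 80000 nM. The expected step that the limit leaves unreadable from compound 1 to compound 3 amounts to essentially none.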

Compound 3, half-maximal inhibitory concentration: > 20000 nM
Compound 3 gave a limit, no number (the forecaster's own chance of this, stated with the estimate: 75%); the middle value does not contradict the limit.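

No step from compound 1 to compound 3 can be read in this assay, because compound 3 gives > 20000 nM, a limit and not a number, as compound 1 does: the limit of > 20000 nM in this assay, at which 2 of the 3 values shown sit.

Left open is whether ethyl and furan-2-yl on a carbonyl carbon differ at all in this assay.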